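This account rests on a few compounds, and the source may have more. Where it says the series, first, only, none or still open, it means among the compounds named here.

Measured so far, in a functional assay on K562 cells (Homo sapiens), read by MTT assay, with a stated time of 72 h; on this read-out higher numbers stand for weaker inhibition and lower numbers for stronger inhibition:
- compound 1 `C#Cc1cn([C@@H]2O[C@H](CO)[C@@H](O)[C@H]2O)c2ncnc(N(C)C)c12` gives 260 nM
- compound 2 `C#Cc1cn([C@@H]2O[C@H](CO)[C@@H](O)[C@H]2O)c2ncnc(SC)c12` gives 70 nM

Compound 1 stands highest of the two numbers; its nearest neighbour is compound 2, reached by a 3.7-fold lower number from compound 1 to compound 2 (0.57 log units; beyond the scatter) on a single exchange of methylsulfanyl for dimethylamino on an aromatic carbon. That step concerns the other substituent of the shared core and leaves the ethynyl group untouched.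

Compound 3 `CN(C)c1ncnc2c1c(-c1cc3ccccc3o1)cn2[C@@H]1O[C@H](CO)[C@@H](O)[C@H]1O` awaits measurement in this assay. Its difference from compound 1 is 1-benzofuran-2-yl in place of ethynyl on an aromatic carbon. Within the data shown here, no measured pair in this small set exchanges the ethynyl group for anything, so the single step on record, although beyond the scatter, bears only indirectly on this change: it shows that the core tolerates a change at one position without loss, and that the numbers of the series sit within a modest span. For the step in question the direction cannot be read from the data, and the expectation is of a step from compound 1 to compound 3 of a 1.7-fold lower number from compound 1 to compound 3 (0.24 log units; within the scatter), with wide uncertainty. Compound 3 is therefore estimated at 150 nM, expected between 30 nM and 1500 nM.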

Compound 3, half-maximal inhibitory concentration: > 20000 nM
Compound 3 was reported as a limit (the forecaster's own chance of this, stated with the estimate: 5%); at least 130-fold (2.12 log units) between middle value and limit.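

In this assay compound 3 gives > 20000 nM, which is a limit of the assay and not a number. The position on the aromatic carbon that carries ethynyl proves far from indifferent to what it bears: 1-benzofuran-2-yl in place of ethynyl brings an at least 76-fold higher number from compound 1 to compound 3 (1.88 log units; beyond the scatter), whereas the earlier change at the other substituent of the shared core brought only a 3.7-fold lower number from compound 1 to compound 2 (0.57 log units; beyond the scatter). The new step therefore marks a large loss whose full size remains undefined: the limit of > 20000 nM in this assay, at which 1 of the 3 values shown sits.

The compounds shown do not tell whether a smaller aromatic group such as furan-2-yl or phenyl, or a short chain such as prop-1-ynyl or hydroxymethyl, would keep the numbers of compound 1 at this position or share the outcome of compound 3, so the boundary between ethynyl and 1-benzofuran-2-yl remains undefined. Also open, from the compounds shown here alone, is whether the same exchange would have a comparable outcome on the methylsulfanyl series represented by compound 2, which gives 70 nM with ethynyl in place.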